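The source may hold more compounds than are shown below. What is called first, only, known or untested is meant among the compounds shown, and "the series" means these compounds.

Measured so far:
Compound 1 `O=C(/C(=C\c1ccc(Cl)cc1)SCc1ccc(Cl)cc1)c1ccc(Br)cc1` — in a functional assay on DU-145 cells (Homo sapiens) for inhibition, read by trypan blue exclusion, with a stated time of 96 h (on this read-out higher numbers stand for weaker inhibition of growth and lower numbers for stronger inhibition of growth), compound 1 gives 10000 nM.
Compound 2 `O=C(/C(=C\c1ccc(Cl)cc1)Sc1ccc(Br)cc1)c1ccc(Br)cc1` — in this assay compound 2 gives 1000 nM.
Compound 3 `COc1ccc(/C=C(/SCc2ccc(Cl)cc2)C(=O)c2ccc(Cl)cc2)cc1` — in this assay compound 3 gives 10000 nM.

Compound 4 `COc1ccc(/C=C(/Sc2ccc(Br)cc2)C(=O)c2ccc(Cl)cc2)cc1` has not yet been measured. It is reached from compound 3 by the change (4-bromophenyl in place of 4-chlorobenzyl on a sulfur). The same change, (4-bromophenyl in place of 4-chlorobenzyl on a sulfur), has already been made once, and it gave the step of a 10-fold lower number from compound 1 to compound 2 (1.00 log units; beyond the scatter). The difference between the core of compound 1 and the core of compound 3 is not broken down here, so the two pairs share a change but not a starting point. Because of a 10-fold lower number from compound 1 to compound 2 (1.00 log units; beyond the scatter), the step from compound 3 to compound 4 is expected to be of roughly the same size, a 10-fold lower number from compound 3 to compound 4 (1.00 log units; beyond the scatter). Compound 4 is therefore estimated at 1000 nM in this assay, within 300 nM to 5000 nM.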

Compound 4, concentration for 50% growth inhibition: 50000 nM
Beside the measured number, compound 4's estimate is 50-fold (1.70 log units) below it; measured number outside the range, above it.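

In this assay putting 4-bromophenyl in place of 4-chlorobenzyl on the sulfur gives a 5.0-fold higher number from compound 3 to compound 4 (0.70 log units; beyond the scatter) and so runs in the opposite direction to the earlier pair: the same change on two cores in this assay, a 10-fold lower number (1.00 log units; beyond the scatter) from compound 1 to compound 2 and a 5.0-fold higher number (0.70 log units; beyond the scatter) from compound 3 to compound 4, 50-fold (1.70 log units) apart, beyond the scatter of two such steps

This shows that, for these two pairs, the outcome of the change depends on the core that carries it, so one pair was not a safe guide to the other. It does not show which part of the difference between the two cores is responsible, or why, as that difference is not broken down here.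

The compounds shown leave open how the change would behave on a third core. They also leave open what a longer chain in place of 4-chlorobenzyl, or an amine or a carboxylic acid on that ring, would do.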